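Swapping Fluoro for Methyl in a Small Series

The compounds below may be only part of what the source reports. "The series", "measured", "known", "first", "only" and "open" are said of these compounds alone.

Within the data shown here, in a functional assay on the whole organism with Mus musculus as the target, in the maximal electroshock model (a lower number here means that less compound is needed, a higher number that more compound is needed for the effect), compound 1 `Cc1ccc(-c2ccc(N3CCC(O)CC3)nn2)c(Cl)c1` gives 21 mg/kg, while compound 2 `OC1CCN(c2ccc(-c3ccc(F)cc3)nn2)CC1` gives 48 mg/kg, the higher of the two numbers and beyond the scatter from its only neighbour. Compound 3 `Cc1ccc(-c2ccc(N3CCC(O)CC3)nn2)cc1` has methyl in place of fluoro on an aromatic carbon, a change counted as methyl in place of fluoro on an aromatic carbon. Among the measured compounds shown here, no measured step isolates this change. Compound 1, which also bears a methyl, stands at 21 mg/kg, which hints at a modest move toward a lower number. The expected step is a 1.4-fold lower number from compound 2 to compound 3 (0.14 log units; within the scatter), within the scatter. For compound 3 the estimated dose is 35 mg/kg, with an expected range of 16 mg/kg to 75 mg/kg.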

Compound 3, dose for half-maximal effect: 73 mg/kg
Beside the measured number, compound 3's estimate is 2.1-fold (0.32 log units) below it; the measured number falls inside the stated range.
By their numbers in this assay, from the lowest: compound 1; then compounds 2 and 3 (each within the scatter of the next).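

In this assay methyl in place of fluoro on an aromatic carbon, para to a large group, gives a 1.5-fold higher number from compound 2 to compound 3 (0.18 log units; within the scatter) and so sets no order between these two groups at this position. Hydrogen in place of chloro on an aromatic carbon gives a 3.5-fold higher number from compound 1 to compound 3 (0.54 log units; beyond the scatter) and is the only one of the two steps that lies beyond the scatter. Nothing in hand explains either step. As far as these compounds go, whether a methoxy group or a nitrile, para to a large group, would stay within the scatter of methyl and fluoro remains open.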